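The source may hold more compounds than are shown below. What is called first, only, known or untested is meant among the compounds shown, and "the series" means these compounds.

Working notes on the series. The core shared by these compounds carries a two-carbonyl four-membered portion and a chain amine; compound 1 is `CC(C)(C)CCNC1C(=O)C(=O)C1Cc1ccc(C#N)cc1`. In a functional assay for inhibition, with Rattus norvegicus as the target (on this read-out higher numbers stand for weaker inhibition and lower numbers for stronger inhibition), compound 1 gives > 30000 nM, which is a limit of the assay and not a number. Compound 3, `CC(C)(C)CCNC1C(=O)C(=O)/C1=C\c1ccc(Br)cc1`, also sits at a limit in this assay, giving > 30000 nM. Compound 2, `CCC(C)(C)/N=c1/c(-c2ccc(C(=O)CCc3ccccc3)cc2)c(O)c1=O`, has in this assay no result reported, so no figure stands for it. Among the compounds with values here, two of the three entries therefore rest at the same limit, and compound 1 is placed only by that boundary, not by a measured number; no step between measured compounds can be stated, and what can be said of compounds 1 and 3 together is only that both values are limits.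

The step from compound 1 to compound 4 introduces compound 4, `COc1ccc(CC2C(=O)C(=O)C2NCCC(C)(C)C)cc1`, with the change (methoxy in place of cyano on an aromatic carbon). The expected step of a number no higher from compound 1 to compound 4 (the limit leaves the size open) is none beyond the scatter, because the limit of > 30000 nM in this assay, at which 2 of the 3 values shown sit, leaves no measured number from which a direction could be read. The estimate for compound 4 in this assay is 30000 nM, within 6000 nM to 150000 nM, and it is expected most likely to be returned as a limit again.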

Compound 4, half-maximal inhibitory concentration: > 30000 nM
Compound 4: only a limit was reported (the forecaster's own chance of this, stated with the estimate: 75%); the middle value sits exactly at the limit.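

No step can be read from compound 1 to compound 4, because the values of both compounds are limits of the assay and not numbers: the limit of > 30000 nM in this assay, at which 3 of the 4 values shown sit.

The compounds shown leave open how strongly any of them inhibits, and whether methoxy in place of cyano on the aromatic carbon changes inhibition at all.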